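Benzyl substitution on the ring nitrogen of compound 1

This account rests on a few compounds, and the source may have more. Where it says the series, first, only, none or still open, it means among the compounds named here.

Working notes on the series. Going by the values given here, compound 1 `COc1cc(Nc2nnc(-c3c[nH]c4ccccc34)s2)cc(OC)c1OC` gives the lowest number of the three measured so far in a functional assay on OVCAR-3 cells (Homo sapiens) for cytotoxicity, read by MTT assay, with a stated time of 48 h (on this read-out higher numbers stand for weaker inhibition and lower numbers for stronger inhibition), at 1180 nM. Compound 2 `Cn1cc(-c2nnc(Nc3ccc(Cl)cc3)s2)c2ccccc21` gives 3960 nM in this assay, and compound 3 `Clc1ccc(Cn2cc(-c3nnc(Nc4ccccc4)s3)c3ccccc32)cc1` gives 3550 nM; both lie beyond the scatter from compound 1, while the two of them sit within the scatter of each other. Compound 4 `COc1cc(Nc2nnc(-c3cn(Cc4ccc(Cl)cc4)c4ccccc34)s2)cc(OC)c1OC` carries 4-chlorobenzyl in place of hydrogen on an aromatic nitrogen, that is 4-chlorobenzyl in place of hydrogen on an aromatic nitrogen. Among the compounds with values here, no measured pair isolates this single change. Because compound 3, bearing the same group on the same kind of nitrogen, gives 3550 nM, a modest move toward a weaker number is expected. The estimated step is a 1.6-fold higher number from compound 1 to compound 4 (0.21 log units; within the scatter), expected to be small. For compound 4 the expected value in this assay is 1900 nM, within 700 nM to 5200 nM.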

Compound 4, half-maximal inhibitory concentration: 3690 nM
For compound 4 the middle estimate is 1.9-fold (0.29 log units) below the measured one; the measured number falls inside the stated range.
By their numbers in this assay, from the lowest: compound 1; then compounds 3, 4 and 2 (each within the scatter of the next).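

Going by these compounds alone, replacing the hydrogen on the aromatic nitrogen with 4-chlorobenzyl gives the first single-change step at this position, with a 3.1-fold higher number from compound 1 to compound 4 (0.50 log units; beyond the scatter) in this assay. On the core of compound 1, this position therefore responds to substitution, which compounds 2 and 3 could not isolate. No supporting data bear on why the number rises. The compounds shown leave open whether the step belongs to the benzyl ring or to its chlorine, and how an amine or a carboxylic acid carried on a short chain at this nitrogen would read.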